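The compounds below may be only part of what the source reports. "The series", "measured", "known", "first", "only" and "open" are said of these compounds alone.

Three compounds have been measured so far:

Compound 1, `CCC(CC)C(=O)Nc1c(C(O)(C(F)(F)F)C(F)(F)F)ccc2ccccc12`: 4340 nM
Compound 2, `N#Cc1cccc(C(=O)Nc2c(C(O)(C(F)(F)F)C(F)(F)F)ccc3ccccc23)c1`: 12 nM
Compound 3, `O=C(Nc1c(C(O)(C(F)(F)F)C(F)(F)F)ccc2ccccc12)c1ccc(F)cc1`: 70 nM

All three share one core and differ only in the group attached to the carbonyl carbon of the amide. In an assay on LtK cells with ATP-sensitive inward rectifier potassium channel 11 (Homo sapiens) as the target (a lower number here means that less compound is needed, a higher number that more compound is needed for the effect), compound 3 gives 70 nM, the second highest of the three numbers; compound 2 gives 12 nM, and compound 1 gives 4340 nM. The step of a 5.8-fold higher number from compound 2 to compound 3 (0.77 log units; beyond the scatter) separates compound 3 from its nearest neighbour, and the step of a 62-fold lower number from compound 1 to compound 3 (1.79 log units; beyond the scatter) separates it from the furthest.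

Compound 4, `O=C(Nc1c(C(O)(C(F)(F)F)C(F)(F)F)ccc2ccccc12)c1ccc(Cl)c(Cl)c1`, has not yet been measured in this assay. It differs from compound 3 in one place: 3,4-dichlorophenyl in place of 4-fluorophenyl on a carbonyl carbon. Two of the measured steps bear on this change. The steps of a 360-fold lower number from compound 1 to compound 2 (2.56 log units; beyond the scatter) and a 62-fold lower number from compound 1 to compound 3 (1.79 log units; beyond the scatter) show that a six-membered aromatic ring of carbon only on the carbonyl carbon gives a far lower number than pentan-3-yl, whichever substituents the ring carries. The step of a 5.8-fold higher number from compound 2 to compound 3 (0.77 log units; beyond the scatter) shows that exchanging one substituted ring for another shifts the number only modestly. Compound 4 keeps such a ring, so the expected step from compound 3 is modest at most, with the direction uncertain: a somewhat lower number seems slightly more likely, but no change beyond the scatter would not be surprising. For compound 4 the expected value in this assay is 40 nM, within a range from 10 nM to 160 nM, which means an expected step of a 1.8-fold lower number from compound 3 to compound 4 (0.24 log units; within the scatter).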

Compound 4, half-maximal effective concentration: 194 nM
Compound 4: the middle estimate sits 4.9-fold (0.69 log units) below what was measured; measured number above the stated range.
By their numbers in this assay, from the lowest: compound 2; then compound 3; then compound 4; then compound 1.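

In this assay, for the compounds shown here, the earlier compounds offered only one exchange of one substituted ring for another, and it was modest, whereas the 3,4-dichlorophenyl group now gives a 2.8-fold higher number from compound 3 to compound 4 (0.44 log units; beyond the scatter) and, more strikingly, a 16-fold higher number from compound 2 to compound 4 (1.21 log units; beyond the scatter). The substituents on the ring can therefore move the number by a large step at this position on the carbonyl carbon, although keeping a six-membered aromatic ring of carbon only still gives a 22-fold lower number from compound 1 to compound 4 (1.35 log units; beyond the scatter), so compound 4 remains well below the pentan-3-yl amide. No measurement of any property of these groups is available to account for this pattern.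

The change in compound 4 removes the fluorine and adds both chlorines in one step, so the compounds shown cannot separate the contribution of each chlorine; 3-chlorophenyl and 4-chlorophenyl on the carbonyl carbon would address that question. Also open, on these data alone, is where an unsubstituted phenyl, or a phenyl ring carrying an amine or a carboxylic acid, would fall.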